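Replacing Fluoro with Acetamido in a Small Cytotoxic Series

This account rests on a few compounds, and the source may have more. Where it says the series, first, only, none or still open, it means among the compounds named here.

Of the compounds shown here, three built on one shared core have been measured so far: compound 1 (`O=C1/C(=C/c2ccccc2F)CN(S(=O)(=O)c2ccc(F)cc2)C/C1=C\c1ccccc1F`), compound 2 (`O=C1/C(=C/c2cccc([N+](=O)[O-])c2)CN(S(=O)(=O)c2ccc(F)cc2)C/C1=C\c1cccc([N+](=O)[O-])c1`) and compound 3 (`COc1cc(/C=C2\CN(S(=O)(=O)c3ccc(F)cc3)C/C(=C\c3cc(OC)cc(OC)c3)C2=O)cc(OC)c1`). In a functional assay on QGY-7703 cells (Homo sapiens) for cytotoxicity, read by MTT assay, with a stated time of 24 h (a higher number here means a weaker inhibitor, a lower number a stronger inhibitor), compound 1 reads 8500 nM while compound 2 reads 11900 nM and compound 3 reads 11400 nM in the same test. Compound 2 therefore stands level with the other two: its gaps to compound 1 and to compound 3 both lie within the usual scatter of repeated measurements, so no order can be read among them.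

Compound 4 (`CC(=O)Nc1ccc(S(=O)(=O)N2C/C(=C\c3cccc([N+](=O)[O-])c3)C(=O)/C(=C/c3cccc([N+](=O)[O-])c3)C2)cc1`) matches compound 2 except at one place, on an aromatic carbon of a six-membered aromatic ring of carbon only, para to a large group. The difference is acetamido in place of fluoro on an aromatic carbon and it amounts to acetamido in place of fluoro. Among the compounds with values here, no measured pair shows this swap directly. Within the data shown here, the only guide is that compound 1 at 8500 nM and compound 3 at 11400 nM stay within the scatter of compound 2 at 11900 nM despite carrying different groups elsewhere, so in this assay no step beyond the scatter is expected, in either direction. The estimated step of a 1.1-fold lower number from compound 2 to compound 4 (0.03 log units; within the scatter) is expected to stay within that scatter. For compound 4 the expected value is 11000 nM with an estimated range from 4500 nM to 27000 nM for this measurement.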

Compound 4, half-maximal inhibitory concentration: 6760 nM
Compound 4: middle estimate off by 1.6-fold (0.21 log units), on the high side; the range from low to high includes it.
By their numbers in this assay, from the lowest: compounds 4, 1, 3 and 2 (each within the scatter of the next).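

In this assay, putting acetamido in place of fluoro on an aromatic carbon, para to a large group, gives a 1.8-fold lower number from compound 2 to compound 4 (0.25 log units; within the scatter). Within the data shown here, compounds 1, 2 and 3 all carry fluoro at this place, so they could say nothing about it; this step is the first direct reading of a change there, and it shows that a group of 4 heavy atoms, with one hydrogen-bond donor and one hydrogen-bond acceptor, can replace a single fluorine without moving the number beyond the scatter of repeated measurements. Nothing measured here offers an explanation for this result.

From the compounds shown here alone, a single swap at one place is only a small sample, so it remains open whether an amine, a carboxylic acid or a longer chain on this aromatic carbon would also stay within the scatter. Going by these compounds, it is equally open whether acetamido in place of fluoro would read the same way with the other groups of compound 1 or compound 3 elsewhere on the shared core.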